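Replacing the hydroxy of compound 3 with a carbamate-bearing amine

The source may hold more compounds than are shown below. What is called first, only, known or untested is meant among the compounds shown, and "the series" means these compounds.

Compound 1 `COc1ccc(/C=C\c2cc(OC)c(OC)c(OC)c2)cc1OCc1ccc(C=O)cc1` gives 800 nM in a functional assay on HepG2 cells (Homo sapiens) for antiproliferative activity, read by CCK-8 assay, with a stated time of 48 h; a lower number here means a stronger inhibitor, a higher number a weaker inhibitor
Compound 2 `COc1ccc(/C=C\c2cc(OC)c(OC)c(OC)c2)cc1OCc1ccc(CN2CCCC[C@H]2C(=O)O)cc1` gives > 10000 nM as a limit in this assay
Compound 3 `COc1ccc(/C=C\c2cc(OC)c(OC)c(OC)c2)cc1OCc1ccc(CN2CCCCC2C(=O)O)cc1` gives 3100 nM in this assay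

Of the two actual numbers, compound 3 holds the higher one, standing above compound 1 (a 3.9-fold higher number from compound 1 to compound 3 (0.59 log units; beyond the scatter)). The entry for compound 2 is only a limit (the limit of > 10000 nM in this assay, at which 1 of the 3 values shown sits). The gap between the two carboxylic acids (an at least 3.2-fold lower number from compound 2 to compound 3 (0.50 log units; beyond the scatter)) goes with one further fact (the fact that one of compounds 2 and 3 is drawn with a defined configuration and the other without, at the place where they differ) and rests on that limit.

Compound 4 `COc1ccc(/C=C\c2cc(OC)c(OC)c(OC)c2)cc1OCc1ccc(CN2CCCCC2C(=O)NCCNC(=O)OC(C)(C)C)cc1` differs from compound 3 by (2-((tert-butoxycarbonyl)amino)ethyl)amino in place of hydroxy on a carbonyl carbon. Within the data shown here, no measured step touches this carbonyl carbon directly. The nearest evidence is the exchange of formyl for (2-carboxypiperidin-1-yl)methyl, which came with higher numbers in both measured cases (an at least 12-fold higher number from compound 1 to compound 2 (1.09 log units; beyond the scatter) and a 3.9-fold higher number from compound 1 to compound 3 (0.59 log units; beyond the scatter)). Compound 4 keeps the ring of that group but not its hydroxy, so part of that rise is expected to be recovered, though with wide uncertainty. A small move toward a lower number is therefore expected (a 2.2-fold lower number from compound 3 to compound 4 (0.35 log units; beyond the scatter)). The estimated value for compound 4 is 1400 nM (expected range 350 nM to 5500 nM).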

Compound 4, half-maximal inhibitory concentration: 1100 nM
Beside the measured number, compound 4's estimate is 1.3-fold (0.10 log units) above it, and the stated range covers the measured number.
By their numbers in this assay, from the lowest: compounds 1 and 4 (each within the scatter of the next); then compound 3. At a limit, above all of these: compound 2.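

In this assay, the carbonyl carbon on the saturated ring carbon tolerates a much larger group than hydroxy: placing (2-((tert-butoxycarbonyl)amino)ethyl)amino there gives a 2.8-fold lower number from compound 3 to compound 4 (0.45 log units; beyond the scatter). Compounds 1, 2 and 3 spoke only to the exchange of formyl for (2-carboxypiperidin-1-yl)methyl and to how one stereocentre is drawn, whereas this step shows that the hydroxy of the carboxylic acid is not needed for activity in this pair, and that an entering group of 11 heavy atoms in place of a single oxygen still moves the number down, if only modestly. Nothing shown here explains why the number falls with this change.

On these data alone, it remains open which part of the entering group goes with the step, and a free primary amine in place of the carbamate, or a longer chain between the two nitrogens, would help to separate those parts. Compound 4 is also drawn without a configuration at the saturated ring carbon, so it is unclear whether the amide drawn as S would follow the acid of compound 2 or keep the number of compound 4.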